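From an azetidine amide to an ethyl ester

A few compounds are considered here, and "the series" means these few. Any claim that something is new, unique, unknown or untested is made for them only; others in the source may bear on it.

The study sets three measured compounds beside one awaiting measurement in a functional assay on HCT-116 cells (Homo sapiens) for inhibition, read by MTT assay, with a stated time of 72 h; on this read-out lower numbers stand for stronger inhibition of growth and higher numbers for weaker inhibition of growth. Compound 1 `COC1CN(C(=O)/C=C/c2ccncc2-c2ccc3ccccc3c2)C1` gives > 30000 nM in this assay, which is a limit of the assay and not a number, as recorded at the limit of > 30000 nM in this assay, at which 1 of the 3 values shown sits. Compound 2 `CNC(=O)/C=C/c1ccncc1-c1ccc2cc[nH]c2c1` gives 10400 nM in this assay. For compound 3 `NC(=O)/C=C/c1ccncc1Nc1ccc(F)cc1` the result in this assay is "not determined" (no result reported). No two of these compounds differ in a single place, so no measured step can be drawn between them. Compound 4 `CCOC(=O)/C=C/c1ccncc1-c1ccc2ccccc2c1` differs from compound 1 by ethoxy in place of 3-methoxyazetidin-1-yl on a carbonyl carbon. Because compound 1 rests at the limit of > 30000 nM in this assay, at which 1 of the 3 values shown sits, the step of a number no higher from compound 1 to compound 4 (the limit leaves the size open) is expected to stay within the scatter, with a limit again likely. Compound 4 is therefore estimated to give 30000 nM in this assay, within 8000 nM to 100000 nM.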

Compound 4, concentration for 50% growth inhibition: 910 nM
Estimate against measurement, compound 4: 33-fold (1.52 log units) above; the whole stated range lies above it.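

In this assay, ethoxy in place of 3-methoxyazetidin-1-yl on a carbonyl carbon gives an at least 32-fold lower number from compound 1 to compound 4 (1.51 log units; beyond the scatter), the first measured sign that the group at this place bears on growth inhibition. The true size of this step stays open, as compound 1 is a limit of the assay and not a number: the limit of > 30000 nM in this assay, at which 1 of the 4 values shown sits.

The compounds shown leave open whether the gain follows from the ethoxy group itself or from the loss of the four-membered ring. A dimethylamino group, a hydroxy group or a longer alkoxy chain on the same carbonyl carbon would bear on that question.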